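The source may report more compounds than this note shows. Statements on the series, on what has been measured and on what is new or still open speak of the compounds shown alone.

Compound 1 `CCCCCCOc1ccc2c(=O)c(-c3ccc(O)cc3)coc2c1` carries a plain hexyloxy chain on the shared core, and in an assay (Cricetulus griseus) for inhibition of aldehyde dehydrogenase, mitochondrial (Homo sapiens) (on this read-out lower numbers stand for stronger inhibition and higher numbers for weaker inhibition), compound 1 gives 1500 nM. Compound 2 `NCCCCCCOc1ccc2c(=O)c(-c3ccc(O)cc3)coc2c1` differs only by the amino group at the far end of that chain, and in this assay compound 2 gives 100 nM, the lowest of the two numbers shown; the step of a 15-fold lower number from compound 1 to compound 2 (1.18 log units; beyond the scatter) is large and beyond the scatter. Compound 3 `O=C(O)CCCCOc1ccc2c(=O)c(-c3ccc(O)cc3)coc2c1` now replaces that end of the chain: carboxy in place of 2-aminoethyl on a saturated chain carbon, four bonds along the chain from an oxygen on an aromatic ring. For the measured compounds named here, the only measured step that bears on this change is the one from compound 1 to compound 2, which shows how much the terminal amino group contributed. Going by the values given here, compound 3 loses that group and gains a carboxy, for which no measured step exists. Compound 3 is therefore expected to show a step of a 15-fold higher number from compound 2 to compound 3 (1.18 log units; beyond the scatter), back toward the level of compound 1, with an estimate of 1500 nM and a range from 400 nM to 6000 nM.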

Compound 3, half-maximal inhibitory concentration: 100 nM
The estimate for compound 3 lay 15-fold (1.18 log units) above the measured number; the whole stated range lies above it.
By their numbers in this assay, from the lowest: compounds 2 and 3 (each within the scatter of the next); then compound 1.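

In this assay, carboxy in place of 2-aminoethyl, on a saturated chain carbon four bonds along the chain from an oxygen on an aromatic ring, gives no change at the digits printed from compound 2 to compound 3 (within the scatter), while carboxy in place of ethyl at the same place gives a 15-fold lower number from compound 1 to compound 3 (1.18 log units; beyond the scatter). The lower level reached with the amino group of compound 2 therefore does not require an amine at the chain end, since a carboxy-ended chain in compound 3 also stands clearly apart from the plain hexyloxy chain of compound 1. No evidence at hand explains why two such different chain ends give this result.

The compounds shown leave open whether a carboxylic acid on a longer chain or an amine on a shorter one would stay at this level. They also leave open how a hydroxyl, an amide or a methyl ester at the chain end would compare.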